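Halogen swap on the phenyl group, measured only at limits

A few compounds are considered here, and "the series" means these few. Any claim that something is new, unique, unknown or untested is made for them only; others in the source may bear on it.

Measured so far in an ADME assay on microsomes from liver (Canis lupus familiaris) for metabolic stability (on this read-out higher numbers stand for a longer-lived compound and lower numbers for a shorter-lived compound), for two compounds
Compound 1 `Nc1nc(NCCNc2ncc(-c3ncc[nH]3)c(-c3ccc(F)cc3C(F)(F)F)n2)ccc1[N+](=O)[O-]` gives > 0.5 h
Compound 2 `Nc1nc(NCCNc2ncc(-c3ncc[nH]3)c(-c3cc(F)c(Cl)cc3Cl)n2)ccc1[N+](=O)[O-]` gives > 0.5 h

Compound 2 stands at > 0.5 h and this is a limit, not a number. Compound 1 also sits at a limit. Within the data shown here, the only measured step is a step that the two limits leave unreadable from compound 1 to compound 2 and it offers no size to carry forward. The evidence stops at the limit of > 0.5 h in this assay, at which 2 of the 2 values shown sit, for now. Compound 3 `Nc1nc(NCCNc2ncc(-c3ncc[nH]3)c(-c3ccc(Cl)cc3Br)n2)ccc1[N+](=O)[O-]` carries 2-bromo-4-chlorophenyl in place of 2,4-dichloro-5-fluorophenyl on an aromatic carbon. No change beyond the scatter is therefore expected in this assay in either direction. The expected step is a step that the limit leaves unreadable from compound 2 to compound 3 as estimated here. Compound 3 is estimated at 0.7 h with an expected range from 0.4 h to 1.4 h for now.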

Compound 3, half-life: > 0.5 h
Compound 3: no number, only a limit (the forecaster's own chance of this, stated with the estimate: 70%); the middle value does not contradict the limit.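

Compound 1, compound 2 and compound 3 each give a limit rather than a number, so no step between them can be read: the limit of > 0.5 h in this assay, at which 3 of the 3 values shown sit.

Going by these compounds, the true half-life of each compound in this assay, and whether these phenyl swaps change it, stays open.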